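The source may hold more compounds than are shown below. What is called first, only, known or untested is meant among the compounds shown, and "the series" means these compounds.

Measured compounds:
compound 1 `COc1ccc(-c2ccc3[nH]c(-c4ccc5[nH]c(-c6ccc7[nH]cnc7c6)nc5c4)nc3c2)cc1` — 90 nM
compound 2 `CCc1nc2cc(-c3nc4cc(-c5nc6cc(-c7ccccc7)ccc6[nH]5)ccc4[nH]3)ccc2[nH]1` — 110 nM

Of the compounds shown here, two have been measured in a functional assay on RPMI 8402 cells (Homo sapiens) for cytotoxicity; a lower number here means a stronger inhibitor, a higher number a weaker inhibitor. Compound 1 gives 90 nM in this assay, and compound 2 gives 110 nM. The two numbers lie within the usual scatter of each other, so compound 2 cannot be set apart from compound 1 on these data; it simply shares the same neighbourhood of potency.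

Compound 3 `CC(C)c1nc2cc(-c3nc4cc(-c5nc6cc(-c7ccccc7)ccc6[nH]5)ccc4[nH]3)ccc2[nH]1` has not been measured. It differs from compound 2 in one place: methyl in place of hydrogen on a saturated chain carbon bound to an aromatic carbon and a saturated chain carbon. Among the compounds with values here, nothing in the measured pair speaks to this particular change, since no two measured compounds differ in one place, and the one comparison available shows two numbers inside the scatter. The change itself is small, one carbon added on a saturated chain carbon bound to an aromatic carbon and a saturated chain carbon.

The step from compound 2 to compound 3 is therefore expected to be small, a 1.1-fold higher number from compound 2 to compound 3 (0.04 log units; within the scatter), not beyond the scatter in either direction. Compound 3 is estimated at 120 nM in this assay, with a range from 60 nM to 250 nM.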

Compound 3, half-maximal inhibitory concentration: 60 nM
For compound 3 the middle estimate is 2.0-fold (0.30 log units) above the measured one; measured number inside the range.
By their numbers in this assay, from the lowest: compounds 3, 1 and 2 (each within the scatter of the next).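

Within the data shown here, the change from ethyl to isopropyl, methyl in place of hydrogen on a saturated chain carbon bound to an aromatic carbon and a saturated chain carbon, gives the first reading of this position in this assay, and it is a 1.8-fold lower number from compound 2 to compound 3 (0.26 log units; within the scatter). An added carbon on this chain is therefore tolerated, with no difference from compound 2 that the data can separate. Nothing available offers an explanation for this reading.

From the compounds shown here alone, whether the same holds for a bulkier chain such as tert-butyl, a ring such as cyclopropyl, or a chain carrying an amine or a carboxylic acid stays open. Also open, going by these compounds, is whether the same change would read alike on the core of compound 1.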